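The compounds below may be only part of what the source reports. "The series", "measured", "known", "first", "only" and "open" are said of these compounds alone.

Measured in a functional assay on MCF7 cells (Homo sapiens) for inhibition, read by MTT assay, with a stated time of 48 h; a higher number here means a weaker inhibitor, a lower number a stronger inhibitor:
- Compound 1 `Cc1ccc(-c2ccnc3c2c(-c2ccccc2)nn3-c2ccccc2)cc1`: 5590 nM
- Compound 2 `COc1ccc(-c2ccnc3c2c(-c2ccccc2)nn3-c2ccccc2)cc1`: 28700 nM

Compound 2 has the higher of the two numbers, which makes it the weaker inhibitor of the pair. Compound 3 `Brc1ccc(-c2ccnc3c2c(-c2ccccc2)nn3-c2ccccc2)cc1` keeps the shared core and changes one group: bromo in place of methoxy on an aromatic carbon. This is bromo in place of methoxy on an aromatic carbon, turning 4-methoxyphenyl into 4-bromophenyl.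

Going by the values given here, only one measured step bears on this change: a 5.1-fold higher number from compound 1 to compound 2 (0.71 log units; beyond the scatter), seen with methoxy in place of methyl. That step is modest but beyond the usual scatter. Among the compounds with values here, no bromo compound has been measured yet, so this support is thin. Removing methoxy may undo part of that rise, so a modest fall in this assay is expected. The estimated change is a 3.2-fold lower number from compound 2 to compound 3 (0.50 log units; beyond the scatter). For compound 3 the expected value is 9000 nM, with an estimated range of 3000 nM to 30000 nM.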

Compound 3, half-maximal inhibitory concentration: 13300 nM
Beside the measured number, compound 3's estimate is 1.5-fold (0.17 log units) below it; measured number inside the range.
By their numbers in this assay, from the lowest: compound 1; then compound 3; then compound 2.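

In this assay, this position on the aromatic ring now has a third group, and the change from 4-methoxyphenyl to 4-bromophenyl gives a 2.2-fold lower number from compound 2 to compound 3 (0.33 log units; beyond the scatter). So methoxy is not the only group that separates from methyl here: bromo also gives a weaker inhibitor than methyl, with a 2.4-fold higher number from compound 1 to compound 3 (0.38 log units; beyond the scatter), and it lands between the other two groups. Nothing measured here explains this order of methyl, bromo and methoxy.

Among these three, compound 1 remains the strongest inhibitor at 5590 nM, and the steps between the three groups are all modest. From the compounds shown here alone, it remains open whether a plain hydrogen, a fluoro group, an amine or a carboxylic acid at this position would give a lower number or a much higher one.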